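Replacing a triazole side chain with a pyrrolidine

The compounds below may be only part of what the source reports. "The series", "measured", "known", "first", "only" and "open" are said of these compounds alone.

Compound 1 `O=C1c2c[n+]([O-])c3ccccc3c2C(=O)c2c1c1ccccc1n2Cc1cn(C[C@H](O)CO)nn1` and compound 2 `O=C1c2c[n+]([O-])c3ccccc3c2C(=O)c2c1c1ccccc1n2Cc1cn(CC(O)CO)nn1` share the same atoms and bonds. In a functional assay on HCT-116 cells (Homo sapiens) for cytotoxicity, read by MTT assay, with a stated time of 72 h (a higher number here means a weaker inhibitor, a lower number a stronger inhibitor), compound 1 gives 400 nM and compound 2 gives 250 nM, two values within the scatter of each other. Among the compounds with values here, on these numbers, then, compound 2 stands level with its only measured neighbour.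

Compound 3 `O=C1c2c[n+]([O-])c3ccccc3c2C(=O)c2c1c1ccccc1n2CCN1CCCC1` keeps the shared core but carries a new side chain: (pyrrolidin-1-yl)methyl in place of 1-(2,3-dihydroxypropyl)-1H-1,2,3-triazol-4-yl on a saturated chain carbon bound to an aromatic nitrogen. Read one bond further out, (1-(2,3-dihydroxypropyl)-1H-1,2,3-triazol-4-yl)methyl gives way to 2-(pyrrolidin-1-yl)ethyl.

Within the data shown here, only one measured step exists, a 1.6-fold lower number from compound 1 to compound 2 (0.20 log units; within the scatter). The sole structural difference behind it is the fact that one of compounds 1 and 2 is drawn with a defined configuration and the other without, at the place where they differ, so it leaves the side chain in place and gives no size for this replacement. With no measured guide, no shift beyond the scatter is expected in this assay, though the uncertainty is wide. The expected change is a 1.7-fold lower number from compound 2 to compound 3 (0.22 log units; within the scatter). For compound 3 the estimated value is 150 nM, with an expected range from 30 nM to 700 nM.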

Compound 3, half-maximal inhibitory concentration: 270 nM
For compound 3 the middle estimate is 1.8-fold (0.26 log units) below the measured one, within the range that was stated.
By their numbers in this assay, from the lowest: compounds 2, 3 and 1 (each within the scatter of the next).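

The earlier pair differed only in how one stereocentre was drawn, so it gave no size for any change of side chain, whereas compound 3 replaces the side chain itself on a saturated chain carbon bound to an aromatic nitrogen. In this assay this replacement gives a 1.1-fold higher number from compound 2 to compound 3 (0.03 log units; within the scatter) and also a 1.5-fold lower number from compound 1 to compound 3 (0.17 log units; within the scatter) and both steps lie within the scatter. The change is not a small one, since 1-(2,3-dihydroxypropyl)-1H-1,2,3-triazol-4-yl, with its aromatic ring and 2 hydrogen-bond donors, gives way to (pyrrolidin-1-yl)methyl, with a non-aromatic ring and 0 hydrogen-bond donors, so among these three compounds cytotoxicity at this position does not depend on which of the two side chains is present.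

As far as these compounds go, whether a morpholine ring, a simple dimethylamine, a carboxylic acid or a longer chain at the same place would also stay within the scatter remains open. Nothing available here explains why two such different side chains give values within the scatter of each other.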